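Bromo on the anilino ring of compound 2

This account rests on a few compounds, and the source may have more. Where it says the series, first, only, none or still open, it means among the compounds named here.

Compound 2 `CCOC(=O)C1=C(Nc2ccccc2)S/C(=C\c2ccc[nH]2)C1=O` gives 49.2% in a functional assay on JAR cells (Homo sapiens) for inhibition, read by MTT assay, with a stated time of 72 h, tested at 10 uM (a lower number here means less inhibition, a higher number more inhibition at the concentration tested (going by the name of the read-out)), the highest of the two numbers in hand; compound 1 `CCOC(=O)C1=C(Nc2ccccc2)S/C(=C\c2ccc(C(=O)O)cc2)C1=O` gives 16.8%. Going by the values given here, the one measured step, a number 32.4 percentage points higher from compound 1 to compound 2 (beyond the scatter), changes the group on the chain carbon, not the anilino ring. Compound 3 `CCOC(=O)C1=C(Nc2ccc(Br)cc2)S/C(=C\c2ccc[nH]2)C1=O` differs from compound 2 by bromo in place of hydrogen on an aromatic carbon. Among the compounds with values here, no measured step touches this ring, so nothing in hand bears on the change. For compound 3 a step within the scatter is expected, a number 0.8 percentage points higher from compound 2 to compound 3 (within the scatter). Compound 3 is therefore estimated at 50%, with a range of 30% to 70%.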

Compound 3, a percentage reported as inhibition, at one concentration (the size of the read-out at that concentration, not a potency): 41.5%
Compound 3: middle estimate off by 8.5 percentage points, on the high side, and the stated range covers the measured number.
By their numbers in this assay, from the lowest: compound 1; then compounds 3 and 2 (each within the scatter of the next).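

The anilino ring now has a measured step: in this assay, bromo in place of hydrogen, para to a large group, gives a number 7.7 percentage points lower from compound 2 to compound 3 (within the scatter). At this position, the change from phenyl to 4-bromophenyl therefore stays within the scatter, whereas the earlier step at the chain carbon lay beyond it. Nothing at hand offers an explanation for this result. The compounds shown leave open how an amine or a carboxylic acid would read at this place on the anilino ring. They also leave open whether the bromo step holds with 4-carboxyphenyl on the chain carbon.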